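Pyrrolidin-1-yl for ethyl on the chlorophenyl urea

A few compounds are considered here, and "the series" means these few. Any claim that something is new, unique, unknown or untested is made for them only; others in the source may bear on it.

Within the data shown here, compound 3 `CCc1ccc(Cl)c(C(=O)NC(=O)Nc2nc3ccc(S(=O)(=O)CCCN4CCN(C)CC4)cc3s2)c1` gives 0.078 nM in an assay on HEK293 cells for displacement of a labelled ligand from growth hormone secretagogue receptor type 1 (Homo sapiens), with a stated time of 60 min (on this read-out lower numbers stand for stronger inhibition and higher numbers for weaker inhibition), the lowest of the three numbers measured so far. Compound 1 `CN1CCN(CCCS(=O)(=O)c2ccc3nc(NC(=O)NC(=O)c4cc(-n5cccc5)ccc4Cl)sc3c2)CC1` sits nearest, giving 0.15 nM in this assay; the gap between the two is within the scatter. Compound 2 `CN1CCC(S(=O)(=O)c2ccc3nc(NC(=O)NC(=O)c4cc(N5CCCC5)ccc4Cl)sc3c2)CC1`, which carries a different sulfonyl substituent, gives 0.92 nM in this assay, a gap to compound 3 that lies beyond the scatter.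

Compound 4 `CN1CCN(CCCS(=O)(=O)c2ccc3nc(NC(=O)NC(=O)c4cc(N5CCCC5)ccc4Cl)sc3c2)CC1` is the next compound to be measured. It differs from compound 3 in one place: pyrrolidin-1-yl in place of ethyl on an aromatic carbon.

Among the measured compounds shown here, one measured step bears on this change: a 1.9-fold lower number from compound 1 to compound 3 (0.28 log units; within the scatter). That step stayed within the scatter, so a change at this position between two groups of comparable size has so far produced no clear movement. Compound 2 carries the same pyrrolidin-1-yl group as compound 4 but on a different sulfonyl side chain, so its number serves only as a loose reference and points toward a somewhat higher value. A modest rise in the number is therefore expected, a 2.6-fold higher number from compound 3 to compound 4 (0.41 log units; beyond the scatter), likely still within the scatter. The estimate for compound 4 is 0.2 nM, with a range from 0.06 nM to 0.7 nM.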

Compound 4, half-maximal inhibitory concentration: 0.29 nM
Estimate against measurement, compound 4: 1.5-fold (0.16 log units) below; the range from low to high includes it.
By their numbers in this assay, from the lowest: compounds 3, 1 and 4 (each within the scatter of the next, the first and the last beyond it); then compound 2.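

In this assay the aromatic carbon para to a chloro group now shows a response to its substituent: a 3.7-fold higher number from compound 3 to compound 4 (0.57 log units; beyond the scatter) is a step beyond the scatter for pyrrolidin-1-yl in place of ethyl, which the earlier step, a 1.9-fold lower number from compound 1 to compound 3 (0.28 log units; within the scatter) for ethyl in place of 1H-pyrrol-1-yl, was not. The two ring-bearing groups do not separate, since a 1.9-fold higher number from compound 1 to compound 4 (0.29 log units; within the scatter) stays within the scatter, so among these three groups only the pair of ethyl and pyrrolidin-1-yl is resolved. Among these compounds, with pyrrolidin-1-yl held fixed, a 3.2-fold lower number from compound 2 to compound 4 (0.50 log units; beyond the scatter) gives the first one-place reading on the sulfonyl sulfur, and 3-(4-methylpiperazin-1-yl)propyl in place of 1-methylpiperidin-4-yl moves the number beyond the scatter, so a change at either end of the series can register in this assay.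

Nothing available accounts for these differences. Still open, on these data alone, is whether a methyl group, a dimethylamino group or a longer chain such as propyl at this aromatic carbon would read with ethyl or with pyrrolidin-1-yl, and whether the sulfonyl step would keep its size with ethyl on the chlorophenyl ring.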